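Chloro in place of hydrogen on compound 3

The source may report more compounds than this note shows. Statements on the series, on what has been measured and on what is new or still open speak of the compounds shown alone.

In a functional assay on HCT-116 cells (Homo sapiens) for antiproliferative activity, read by MTT assay, with a stated time of 48 h (a lower number here means a stronger inhibitor, a higher number a weaker inhibitor), compound 3 (`CCCCCCCCCC(CCO)n1cnc2c(N)ncnc21`) gives 10500 nM, within the scatter of compound 2 (`CCCCCCCCC(CCO)n1cnc2c(N)nc(Cl)nc21`) at 21000 nM. Compound 1 (`CCCCCCCC(CCO)n1cnc2c(N)nc(Cl)nc21`) is recorded only as a limit, > 50000 nM. Compound 4 (`CCCCCCCCCC(CCO)n1cnc2c(N)nc(Cl)nc21`) keeps the chain of compound 3 but carries chloro in place of hydrogen on an aromatic carbon, between two ring nitrogen atoms (chloro in place of hydrogen on an aromatic carbon). For the measured compounds named here, no measured step makes this exchange. The nearest evidence is an at least 2.3-fold lower number from compound 1 to compound 2 (0.37 log units; beyond the scatter), a chain step between two chloro compounds, so compound 4 is expected to give a lower number than compound 2 at 21000 nM. In this assay, no step beyond the scatter is therefore expected, and the estimated change is a 1.2-fold lower number from compound 3 to compound 4 (0.07 log units; within the scatter). The estimate for compound 4 is 9000 nM, with an expected range of 3500 nM to 22000 nM.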

Compound 4, half-maximal inhibitory concentration: 14800 nM
Beside the measured number, compound 4's estimate is 1.6-fold (0.22 log units) below it; measured number inside the range.
By their numbers in this assay, from the lowest: compounds 3, 4 and 2 (each within the scatter of the next). At a limit, above all of these: compound 1.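

On this chain, chloro in place of hydrogen on an aromatic carbon, between two ring nitrogen atoms, leaves the result within the scatter (a 1.4-fold higher number from compound 3 to compound 4 (0.15 log units; within the scatter)). With chloro kept, the methyl step on the chain is also within the scatter (a 1.4-fold lower number from compound 2 to compound 4 (0.15 log units; within the scatter)), while the ethyl step lies beyond it (an at least 3.3-fold lower number from compound 1 to compound 4 (0.52 log units; beyond the scatter)). That larger step starts from compound 1, which is recorded only as a limit: the limit of > 50000 nM in this assay, at which 1 of the 4 values shown sits. The compounds shown leave open whether an amine or a methoxy group on this aromatic carbon, or a longer chain, would give a number beyond the scatter of compound 3.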